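A Larger Ring on the Sulfonyl Chain

The source may hold more compounds than are shown below. What is called first, only, known or untested is meant among the compounds shown, and "the series" means these compounds.

In a functional assay, read by fluorescence and spectrophotometry, with a stated time of 1 h (a lower number here means that less compound is needed, a higher number that more compound is needed for the effect), compound 3 `O=S(=O)(/C=C/c1ccc(O)c(O)c1)CCCC1CCCC1` gives 6300 nM and sits within the scatter of compound 1 `C=CCCCCCCCS(=O)(=O)/C=C/c1ccc(O)c(O)c1` at 6900 nM and compound 2 `CCCCCS(=O)(=O)/C=C/c1ccc(O)c(O)c1` at 8100 nM in the same test. Compound 4 `O=S(=O)(/C=C/c1ccc(O)c(O)c1)CCCC1CCCCC1` carries cyclohexyl in place of cyclopentyl on a saturated chain carbon, three bonds along the chain from a sulfonyl sulfur on the same chain carbon. For the measured compounds named here, three measured steps bear on this, each a change in the sulfonyl chain: a 1.1-fold lower number from compound 1 to compound 3 (0.04 log units; within the scatter) and a 1.3-fold lower number from compound 2 to compound 3 (0.11 log units; within the scatter) and also a 1.2-fold higher number from compound 1 to compound 2 (0.07 log units; within the scatter) all stay within the scatter. No step beyond the scatter is therefore expected in this assay for this smaller change. The expected step is a 1.1-fold lower number from compound 3 to compound 4 (0.02 log units; within the scatter) and no more. For compound 4 the estimate is 6000 nM with an expected range from 3000 nM to 12000 nM in this test.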

Compound 4, half-maximal effective concentration: 7900 nM
For compound 4 the middle estimate is 1.3-fold (0.12 log units) below the measured one, within the range that was stated.
By their numbers in this assay, from the lowest: compounds 3, 1, 4 and 2 (each within the scatter of the next).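

In this assay, going from a five-membered to a six-membered carbon ring at this place on the chain leaves the result within the scatter, with a 1.3-fold higher number from compound 3 to compound 4 (0.10 log units; within the scatter). The cyclohexyl compound also stays within the scatter of the two open-chain compounds, with a 1.0-fold lower number from compound 2 to compound 4 (0.01 log units; within the scatter) and with a 1.1-fold higher number from compound 1 to compound 4 (0.06 log units; within the scatter), so all the chain ends shown here read alike. Nothing measured here offers a reason for this. Every chain end shown contains only carbon and hydrogen. As far as these compounds go, whether an amine or a carboxylic acid at this place would move the number beyond the scatter remains open.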